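Changing one aryl group on a potent growth inhibitor

The source may hold more compounds than are shown below. What is called first, only, known or untested is meant among the compounds shown, and "the series" means these compounds.

Of the compounds shown here, three have been measured in a functional assay on DU-145 cells (Homo sapiens) for inhibition, read by trypan blue exclusion, with a stated time of 96 h; a higher number here means a weaker inhibitor of growth, a lower number a stronger inhibitor of growth. Compound 1 `O=C(/C(=C\c1c(O)cc(O)cc1O)S(=O)(=O)c1ccccc1Br)c1ccc(Br)cc1` gives 50000 nM, and compound 3 `Cc1ccc(/C=C(/SCc2ccc(Cl)cc2)C(=O)c2ccc([N+](=O)[O-])cc2)s1` gives 25000 nM. Compound 2 `O=C(/C(=C\c1ccc([N+](=O)[O-])c(O)c1)SCc1ccc(Br)cc1)c1ccc(C(F)(F)F)cc1` gives 1000 nM, the lowest of the three numbers. A lower number means stronger inhibition, so compound 2 is the strongest of this small set, and its gap to each of the other two lies beyond the scatter of repeated measurements. Within the data shown here, these three compounds differ in more than one place, so no measured pair shows what a single change does.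

Compound 4 `O=C(/C(=C\c1ccc([N+](=O)[O-])c(O)c1)SCc1ccc(Br)cc1)c1c(F)c(F)c(F)c(F)c1F` differs from compound 2 in one place, on a carbonyl carbon: 2,3,4,5,6-pentafluorophenyl in place of 4-(trifluoromethyl)phenyl on a carbonyl carbon. Both groups are a six-membered aromatic ring of carbon only that carries fluorine, and neither has a net charge. Among the measured compounds shown here, with no measured step as a guide, only a small shift toward weaker inhibition in this assay is expected, because compound 2 at 1000 nM already holds the lowest number of the set, so a change is more likely to raise it than lower it. The expected step is small, at a 2.5-fold higher number from compound 2 to compound 4 (0.40 log units; beyond the scatter). For compound 4, the estimated value is 2500 nM, with an expected range of 600 nM to 10000 nM.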

Compound 4, concentration for 50% growth inhibition: 10000 nM
Compound 4: middle estimate off by 4.0-fold (0.60 log units), on the low side; the measured number falls inside the stated range.
By their numbers in this assay, from the lowest: compound 2; then compound 4; then compounds 3 and 1 (each within the scatter of the next).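

Among these compounds, this step is the first direct view of this position: with the rest of compound 2 held fixed, putting 2,3,4,5,6-pentafluorophenyl in place of 4-(trifluoromethyl)phenyl on the carbonyl carbon in this assay gives a 10-fold higher number from compound 2 to compound 4 (1.00 log units; beyond the scatter), so growth inhibition weakens. The two groups are alike in several printed respects, as each is a six-membered aromatic ring of carbon only that carries fluorine, with no hydrogen-bond donors or acceptors and no net charge, yet that likeness does not make them interchangeable at this place. No measurement is available that explains the step, so its reason remains unknown.

From the compounds shown here alone, how a plain phenyl, a 4-fluorophenyl or a 4-aminophenyl group would behave on this carbonyl carbon remains open, as does whether any group there could give a number lower than that of compound 2, at 1000 nM. This evidence comes from a single pair, so it also leaves open whether the same exchange would have a similar effect on a different core, such as that of compound 1.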